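Methoxy on the fused ring of compound 1

This account rests on a few compounds, and the source may have more. Where it says the series, first, only, none or still open, it means among the compounds named here.

The series rests on two measured compounds. Compound 1 `COc1ccc(-c2[nH]c3ccccc3c2/C=C(\C#N)S(=O)(=O)c2ccccc2)cc1` gives, in a functional assay on M14 cells (Homo sapiens) for inhibition, read by sulforhodamine B assay, with a stated time of 48 h (on this read-out higher numbers stand for weaker inhibition of growth and lower numbers for stronger inhibition of growth), 383 nM. Compound 2 `COc1ccc2[nH]c(-c3ccccc3)c(C=C(C#N)C#N)c2c1` gives in this assay 2300 nM. Compound 1 thus holds the lowest of the two numbers; compound 2 is its nearest neighbour, and the gap between them lies beyond the usual scatter. Among the compounds with values here, compound 2 differs from compound 1 in more than one place, so no single step between measured compounds is available; the two values show only that compound 1 inhibits growth more strongly than compound 2.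

Compound 3 `COc1ccc(-c2[nH]c3ccc(OC)cc3c2/C=C(\C#N)S(=O)(=O)c2ccccc2)cc1` is not yet measured. It differs from compound 1 in one place: methoxy in place of hydrogen on an aromatic carbon. Within the data shown here, no measured pair isolates this change, and the measured set gives no ground for a shift in either direction. The expected step is therefore a 1.0-fold higher number from compound 1 to compound 3 (0.02 log units; within the scatter), that is, none beyond the scatter. Compound 3 is estimated at 400 nM in this assay, with a range from 150 nM to 1200 nM, the width reflecting the absence of any matched pair for this change.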

Compound 3, concentration for 50% growth inhibition: 500 nM
The estimate for compound 3 lay 1.3-fold (0.10 log units) below the measured number; the range from low to high includes it.
By their numbers in this assay, from the lowest: compounds 1 and 3 (each within the scatter of the next); then compound 2.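

In this assay, within the data shown here, methoxy in place of hydrogen on an aromatic carbon of the fused system gives a 1.3-fold higher number from compound 1 to compound 3 (0.12 log units; within the scatter), and this is the first pair that isolates this change. The position, meta to a fused ring and para to a fused ring, therefore accepts methoxy with no shift beyond the scatter, so compound 1 and compound 3 cannot be ranked against each other on this read-out. This rests on a single matched pair, and nothing available bears on why the number holds at this position.

Open, going by these compounds, is whether this acceptance extends beyond methoxy, for instance to a longer chain such as butoxy, to an amine or to a carboxylic acid on the same aromatic carbon. Also open, on these data alone, is whether methoxy on the other aromatic carbons of this six-membered ring would likewise stay within the scatter of compound 1, since the pair speaks for one place and one group only.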